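A Small Amine Gives Way to a Much Larger Group

The source may report more compounds than this note shows. Statements on the series, on what has been measured and on what is new or still open speak of the compounds shown alone.

Compound 1 `CNC(=N)Nc1nc(-c2ccc(OC)cc2)c(-c2ccc(OC)cc2)s1` gives 62 nM in a functional assay with Oryctolagus cuniculus as the target; a higher number here means a weaker inhibitor, a lower number a stronger inhibitor
Compound 2 `COc1ccc(-c2nc(CN(C)C)sc2-c2ccc(OC)cc2)cc1` gives 96 nM in this assay

Going by the values given here, compound 2, at 96 nM, stands within the scatter of compound 1, at 62 nM, the only other compound measured so far. Compound 3 `COc1ccc(-c2nc(CNC(=O)C3=NNC(=O)CC3)sc2-c2ccc(OC)cc2)cc1` differs from compound 2 by a group of 10 heavy atoms (5 carbon, 3 nitrogen, 2 oxygen; one six-membered non-aromatic ring with 2 hetero atoms) in place of a group of 3 heavy atoms (2 carbon, 1 nitrogen; no ring), on a saturated chain carbon bound to an aromatic carbon and so brings one six-membered non-aromatic ring into the molecule. Among the compounds with values here, only one measured step bears on this change, a 1.5-fold higher number from compound 1 to compound 2 (0.19 log units; within the scatter), and it is a weak guide. That step exchanged two groups of similar size on an aromatic carbon, whereas the new group is far larger and stands on a saturated chain carbon. Nothing measured shows how a group of this size behaves at that place, so only a modest move toward a higher number is expected, with wide uncertainty. The expected size of the move is a 1.6-fold higher number from compound 2 to compound 3 (0.19 log units; within the scatter) in this estimate. In this assay compound 3 is estimated at 150 nM, with a range from 30 nM to 800 nM expected.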

Compound 3, half-maximal inhibitory concentration: 55 nM
Compound 3: middle estimate off by 2.7-fold (0.44 log units), on the high side, within the range that was stated.
By their numbers in this assay, from the lowest: compounds 3, 1 and 2 (each within the scatter of the next).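

At the saturated chain carbon bound to an aromatic carbon, dimethylamino gives way to a group of 10 heavy atoms with one six-membered non-aromatic ring with 2 hetero atoms, and in this assay this change amounts to a 1.7-fold lower number from compound 2 to compound 3 (0.24 log units; within the scatter) in the read-out. The earlier compounds shown here offered only an exchange of two groups of similar size on an aromatic carbon, whereas this step shows that a far larger group, with 2 hydrogen-bond donors and 3 hydrogen-bond acceptors against the 0 donors and 1 acceptor of dimethylamino, can stand at this place with the number staying within the scatter. Nothing available here bears on what lies behind this result.

The single step replaces the whole group at once, so the compounds shown do not separate the contribution of the amide carbonyl from that of the ring, a question that a plain acetamide on the same chain carbon could address. Also open, from the compounds shown here alone, is whether a primary amine, a carboxylic acid or a longer chain at this place would likewise keep the number within the scatter.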